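This account rests on a few compounds, and the source may have more. Where it says the series, first, only, none or still open, it means among the compounds named here.

Series in an ADME assay on the whole organism (plasma) for metabolic stability, with Rattus norvegicus as the target; a lower number here means that the compound disappears faster, a higher number that the compound lasts longer:
- compound 1 `COC(=O)c1cc(C(=CCCCc2ccccc2)c2cc(Br)c(OC)c(C(=O)OC)c2)cc(Br)c1OC`: 0.917 h
- compound 2 `CCCOC(=O)CCCC=C(c1cc(Br)c(OC)c(C(=O)OC)c1)c1cc(Br)c(OC)c(C(=O)OC)c1`: 0.0567 h

Among the measured compounds shown here, compound 2 is the lower of the two, and compound 1 is its only neighbour. Compound 3 `COC(=O)c1cc(C(=CCCCC(=O)OC(C)C)c2cc(Br)c(OC)c(C(=O)OC)c2)cc(Br)c1OC` differs from compound 2 by isopropyl in place of propyl on an oxygen next to a carbonyl group. For the measured compounds named here, the one measured step, a 16-fold lower number from compound 1 to compound 2 (1.21 log units; beyond the scatter), bears only indirectly, since it swaps phenyl for propoxycarbonyl and does not vary the propyl. A small rise in this assay is expected, far smaller than that step. The expected step is a 2.1-fold higher number from compound 2 to compound 3 (0.33 log units; beyond the scatter). Compound 3 is estimated at 0.12 h, with an expected range of 0.05 h to 0.4 h.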

Compound 3, half-life: 0.095 h
For compound 3 the middle estimate is 1.3-fold (0.10 log units) above the measured one, and the stated range covers the measured number.
By their numbers in this assay, from the lowest: compounds 2 and 3 (each within the scatter of the next); then compound 1.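

In this assay, isopropyl in place of propyl on an oxygen next to a carbonyl group gives a 1.7-fold higher number from compound 2 to compound 3 (0.22 log units; within the scatter), so this change does not separate the two esters beyond the scatter. Isopropoxycarbonyl in place of phenyl gives a 9.7-fold lower number from compound 1 to compound 3 (0.98 log units; beyond the scatter), so the large gap seen with the propyl ester also holds with a second ester. No evidence bears on the reason for either step.

Open, from the compounds shown here alone, is whether a tert-butyl group on that oxygen would stay with compound 2 and compound 3. Also open, going by these compounds, is where an amide or a carboxylic acid at that chain end would fall relative to compound 1.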